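Chloro for Methyl: Estimating Compound 4

This account rests on a few compounds, and the source may have more. Where it says the series, first, only, none or still open, it means among the compounds named here.

All three measured compounds were tested in a functional assay on Ehrlich cells (Mus musculus) for cytotoxicity, read by trypan blue exclusion, with a stated time of 48 h; a lower number here means a stronger inhibitor, a higher number a weaker inhibitor:
compound 1, `Cc1ccc(-c2csc(NC(=O)COc3ccccc3)n2)cc1`, gives 49800 nM;
compound 2, `O=C(COc1ccccc1)Nc1nc(-c2ccc(Cl)cc2)cs1`, gives 56800 nM;
compound 3, `Cc1ccc(OCC(=O)Nc2nc(-c3ccc(C)cc3)cs2)cc1`, gives 45100 nM.

Compound 3 differs from compound 1 by methyl in place of hydrogen on an aromatic carbon. Compound 4, `Cc1ccc(-c2csc(NC(=O)COc3ccc(Cl)cc3)n2)cc1`, has not yet been measured; it differs from compound 3 by chloro in place of methyl on an aromatic carbon. The same kind of change is already measured once, from compound 1 to compound 2, as chloro in place of methyl on an aromatic carbon, and there it gave a 1.1-fold higher number from compound 1 to compound 2 (0.06 log units; within the scatter). Both changes sit at a place described in the same words, so the change is taken as the same. Because a 1.1-fold higher number from compound 1 to compound 2 (0.06 log units; within the scatter) lies within the scatter, a similarly small step is expected here. Compound 4 is expected to show a step of a 1.1-fold higher number from compound 3 to compound 4 (0.04 log units; within the scatter). In this assay compound 4 is estimated at 50000 nM, with a likely range from 28000 nM to 90000 nM.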

Compound 4, half-maximal inhibitory concentration: 42000 nM
Estimate against measurement, compound 4: 1.2-fold (0.08 log units) above; the range from low to high includes it.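

The new step, a 1.1-fold lower number from compound 3 to compound 4 (0.03 log units; within the scatter), is as small as the earlier one, and the related swap of chloro for hydrogen gives a 1.2-fold lower number from compound 1 to compound 4 (0.07 log units; within the scatter). In this assay, the two chloro-for-methyl steps cannot be told apart: the same change on two cores in this assay, a 1.1-fold higher number (0.06 log units; within the scatter) from compound 1 to compound 2 and a 1.1-fold lower number (0.03 log units; within the scatter) from compound 3 to compound 4, 1.2-fold (0.09 log units) apart, within the scatter of two such steps. This shows that the swap leaves the number within the scatter on both cores, but it does not show that a real effect carries from one core to another, and two cores are a small sample.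

On these data alone, it remains open whether a different group at these places, such as an amine or a carboxylic acid, would move the number beyond the scatter. A longer chain between the amide and the phenoxy oxygen is equally untested here.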